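Imidazole in place of methoxy on the chalcone series

The source may hold more compounds than are shown below. What is called first, only, known or untested is meant among the compounds shown, and "the series" means these compounds.

Values in a functional assay on HeLa cells (Homo sapiens) for inhibition, read by MTT assay, with a stated time of 72 h (on this read-out higher numbers stand for weaker inhibition and lower numbers for stronger inhibition), for the compounds measured so far
- compound 1 (`COc1ccc(C(=O)/C=C/c2cc(OC)c(OC)cc2OC)cc1`) gives 37600 nM
- compound 2 (`COc1cc(OC)c(-c2cc(=O)c3ccc(O)cc3o2)cc1OC`) gives > 150000 nM as a limit of the assay
- compound 3 (`COc1cc(OC)c(OC)cc1/C=C/C(=O)c1cc(Cc2ccccc2)cc(Cc2ccccc2)c1`) gives 26900 nM

Going by the values given here, compound 1 at 37600 nM lies within the scatter of compound 3, and these are the only two true numbers in hand. The value of compound 2 is a limit, as the limit of > 150000 nM in this assay, at which 1 of the 3 values shown sits, records, and gives no number to compare.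

Compound 4 (`COc1cc(OC)c(OC)cc1/C=C/C(=O)c1ccc(-c2c[nH]cn2)cc1`) carries 1H-imidazol-4-yl in place of methoxy on an aromatic carbon, para to a large group (1H-imidazol-4-yl in place of methoxy on an aromatic carbon). Among the compounds with values here, no measured pair covers this change, so the expectation rests on thin ground. Against compound 1, compound 3 also differs on the side of the carbonyl away from the trimethoxy-bearing end and gives 26900 nM, which stays within the scatter. A modest step in this assay toward a lower number, meaning stronger inhibition, is therefore expected, though no change beyond the scatter remains possible. The estimated value for compound 4 is 15000 nM with an expected range from 3000 nM to 70000 nM in this series. The expected size is a 2.5-fold lower number from compound 1 to compound 4 (0.40 log units; beyond the scatter) as estimated here.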

Compound 4, half-maximal inhibitory concentration: > 150000 nM
Compound 4 gave a limit, no number; the forecaster's own chance of this, stated with the estimate: 8%; middle value at least 10-fold (1.00 log units) away from the limit.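

In this assay, the exchange of methoxy for 1H-imidazol-4-yl on this aromatic carbon, para to a large group, gives an at least 3.9-fold higher number from compound 1 to compound 4 (0.60 log units; beyond the scatter), a step beyond the scatter toward weaker inhibition. Going by these compounds alone, this is the first change that can be read in one place, and it shows that the position is not indifferent to what it carries: this five-membered aromatic ring with 2 hetero atoms does not keep the inhibition seen with methoxy. Compound 4 gives a limit and not a number, so the step has a lower bound but no measured size: the limit of > 150000 nM in this assay, at which 2 of the 4 values shown sit.

The compounds shown do not separate the effect of the ring itself from that of its two nitrogens, since a phenyl ring at the same carbon does not appear among them. Also open, as far as these compounds go, is whether a smaller replacement for methoxy, such as an amine or a carboxylic acid, would stay near compound 1 at 37600 nM or fall away as well.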